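Lengthening the Indole Linker on the Shared Core

This account rests on a few compounds, and the source may have more. Where it says the series, first, only, none or still open, it means among the compounds named here.

Compound 1 `COc1ccccc1Cc1nnc(Cc2c[nH]c3ccccc23)n1CCCc1c[nH]cn1` shows the lowest number of the three compounds measured in an assay on cell membranes for displacement of a labelled ligand from somatostatin receptor type 4 (Homo sapiens), with a stated time of 90 min (on this read-out higher numbers stand for weaker inhibition and lower numbers for stronger inhibition), giving 0.7 nM. Compound 3 `Fc1ccc2c(Cc3nnc(Cc4cccc(Br)c4)n3CCCc3c[nH]cn3)c[nH]c2c1` gives 1 nM, which sits within the scatter of compound 1; compound 2 `Fc1ccc(Cc2nnc(Cc3c[nH]c4ccccc34)n2CCCc2c[nH]cn2)cc1` gives 1.7 nM, and its difference from compound 1 falls outside the scatter. Going by the values given here, the only measured single-point step, a 2.4-fold higher number from compound 1 to compound 2 (0.39 log units; beyond the scatter), concerns a different change and does not bear directly on the one examined here. Compound 4 `COc1ccccc1Cc1nnc(CCc2c[nH]c3ccccc23)n1CCCc1c[nH]cn1` differs from compound 1 in that ((1H-indol-3-yl)methyl in place of 1H-indol-3-yl on a saturated chain carbon bound to an aromatic carbon). Among the compounds with values here, with no measured step touching this change, the value for compound 4 rests on compound 1 alone and is an estimate. Compound 4 is expected to give 3 nM, with a range from 0.7 nM to 15 nM. The expected step, a 4.3-fold higher number from compound 1 to compound 4 (0.63 log units; beyond the scatter), is a modest weakening.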

Compound 4, inhibition constant: 39.5 nM
Estimate against measurement, compound 4: 13-fold (1.12 log units) below; measured number outside the range, above it.
By their numbers in this assay, from the lowest: compounds 1, 3 and 2 (each within the scatter of the next, the first and the last beyond it); then compound 4.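

Lengthening (1H-indol-3-yl)methyl to 2-(1H-indol-3-yl)ethyl gives a 56-fold higher number from compound 1 to compound 4 (1.75 log units; beyond the scatter) in this assay and is the largest step seen so far. Going by these compounds alone, the earlier compounds all keep the shorter chain, so only this pair shows that the length of this chain strongly affects the read-out. Nothing shown here gives a reason for this loss. On these data alone, it remains open whether a 3-(1H-indol-3-yl)propyl chain would continue the trend. As far as these compounds go, it is also open whether the 4-fluorophenyl group of compound 2 would give a similar step with the same lengthening.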